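A few compounds are considered here, and "the series" means these few. Any claim that something is new, unique, unknown or untested is made for them only; others in the source may bear on it.

Of the compounds shown here, three built on one shared core have been measured so far. Compound 1 `Cc1cccc(-c2noc([C@@H](C)NC(=O)c3cc(C4CC4)nn3C)n2)c1` gives 3310 nM in an assay on T-REx-293 cells for inhibition of potassium channel subfamily T member 1 (Homo sapiens), read by patch clamp; on this read-out higher numbers stand for weaker inhibition and lower numbers for stronger inhibition. Compound 2 `Cc1cccc(-c2nc(C(C)NC(=O)c3cc(C(F)(F)F)nn3C)no2)c1` gives 977 nM in this assay, and compound 3 `Cc1cncc(-c2noc([C@H](C)NC(=O)c3cc(C(F)(F)F)nn3C)n2)c1` gives 1370 nM. Compound 3 thus stands second highest of the three numbers: its gap to compound 2 lies within the scatter, while its gap to compound 1 lies beyond it, with compound 1 showing the higher number. Compound 4 `C[C@H](NC(=O)c1cc(C(F)(F)F)nn1C)c1nc(-c2ccccn2)no1` is not yet measured; it differs from compound 3 by pyridin-2-yl in place of 5-methylpyridin-3-yl on an aromatic carbon. Among the compounds with values here, no measured pair shows such a change, so no step beyond the scatter is expected in either direction. For compound 4 the estimate in this assay is 1800 nM, with a range from 600 nM to 5500 nM, which means an expected step of a 1.3-fold higher number from compound 3 to compound 4 (0.12 log units; within the scatter).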

Compound 4, half-maximal inhibitory concentration: > 30000 nM
Compound 4 gave a limit, no number (the forecaster's own chance of this, stated with the estimate: 5%); middle value at least 16-fold (1.22 log units) away from the limit.
By their numbers in this assay, from the lowest: compounds 2 and 3 (each within the scatter of the next); then compound 1. At a limit, above all of these: compound 4.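

Putting pyridin-2-yl in place of 5-methylpyridin-3-yl at this position gives an at least 21-fold higher number from compound 3 to compound 4 (1.34 log units; beyond the scatter) in this assay, so this position is far from indifferent to the aryl group it carries. The two groups count alike in aromatic rings, hetero atoms, donors and acceptors, yet the change is large. Compound 4 gives a limit of the assay, not a number: the limit of > 30000 nM in this assay, at which 1 of the 4 values shown sits.

From the compounds shown here alone, whether the step follows the lost methyl or the changed place of the ring nitrogen stays open, and a plain pyridin-3-yl would separate the two. Going by these compounds, how an amine on this ring would read is also open.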